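Urea to amide on the shared core: compound 4

The source may report more compounds than this note shows. Statements on the series, on what has been measured and on what is new or still open speak of the compounds shown alone.

Measured so far in a functional assay on IGROV-1 cells (Homo sapiens) for inhibition, read by sulforhodamine B assay, with a stated time of 48 h, tested at 10 uM; a higher number here means a weaker effect of the compound at the concentration tested, a lower number a stronger effect:
compound 1, `COc1cc(Cl)cc(-c2nn(-c3cccc(NC(=O)Nc4cccc(C(F)(F)F)c4)c3)cc2-c2ccncc2)c1`, 28.9%
compound 2, `COc1cc(Cl)cc(-c2nn(-c3cccc(NC(=O)Nc4ccc(Cl)c(C(F)(F)F)c4)c3)cc2-c2ccncc2)c1`, 30.2%
compound 3, `COc1cc(Cl)cc(-c2nn(-c3cccc(NC(=O)c4cc(C(F)(F)F)cc(C(F)(F)F)c4)c3)cc2-c2ccncc2)c1`, 100%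

Compound 2 holds the second highest of the three numbers in this assay. Its nearest neighbour is compound 1, whose number lies lower by a number 1.3 percentage points higher from compound 1 to compound 2 (within the scatter), a step that comes from chloro in place of hydrogen on an aromatic carbon and stays within the scatter. Its furthest neighbour is compound 3, whose number stands far above it, beyond the scatter; compound 3 carries an amide on the shared core where compound 1 and compound 2 carry a urea.

Compound 4, `COc1cc(Cl)cc(-c2nn(-c3cccc(NC(=O)c4ccc(Cl)c(Cl)c4)c3)cc2-c2ccncc2)c1`, is not yet measured. It differs from compound 2 in one place: 3,4-dichlorophenyl in place of (4-chloro-3-(trifluoromethyl)phenyl)amino on a carbonyl carbon. Within the data shown here, no measured step matches this change directly. Among the measured compounds shown here, the only bearing comes from compound 3, the one amide in the set, whose number in this assay shows no effect at the test concentration, while both ureas sit far lower. On that basis compound 4 is expected to move towards compound 3, a rise by about a number 54.8 percentage points higher from compound 2 to compound 4 (beyond the scatter). Compound 4 is therefore estimated at 85%, within a range from 55% to 105%.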

Compound 4, a percentage reported as activity, at one concentration (the size of the read-out at that concentration, not a potency): 71.6%
Beside the measured number, compound 4's estimate is 13.4 percentage points above it, and the stated range covers the measured number.
By their numbers in this assay, from the lowest: compounds 1 and 2 (each within the scatter of the next); then compound 4; then compound 3.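

The second amide confirms what compound 3 alone could only suggest: in this assay, placing 3,4-dichlorophenyl on the carbonyl carbon in place of the substituted phenylamino group of the ureas gives a large loss of effect, seen both in a number 41.4 percentage points higher from compound 2 to compound 4 (beyond the scatter) and in a number 42.7 percentage points higher from compound 1 to compound 4 (beyond the scatter). Among the four compounds, both amides stand above both ureas, and no compound goes against this, but compound 4 at 71.6% shows that an amide here need not reach the level of compound 3 at 100%. Nothing offered here accounts for these steps.

Each step removes the amino nitrogen and also changes the substituents on the aromatic ring, so the share of each change in the rise remains unresolved, and no urea and amide shown carry the same aromatic ring. Also open, from the compounds shown here alone, is how the carbonyl carbon would fare with a methylene group or the oxygen of a carbamate in place of the amino nitrogen, or with a sulfonamide in place of the whole urea.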